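The source may report more compounds than this note shows. Statements on the series, on what has been measured and on what is new or still open speak of the compounds shown alone.

Compound 1 `CCc1ccc(C(=O)NN(C(=O)c2ccccc2)C(C)(C)C)cc1`: in an assay on cells for agonist activity at ecdysone receptor (Bombyx mori), read by a luciferase reporter, with a stated time of 24 h (a higher number here means that more compound is needed for the effect, a lower number that less compound is needed), compound 1 gives 4.9 nM
Compound 2 `CCc1ccc(C(=O)NN(C(=O)CCC(C)C)C(C)(C)C)cc1`: in this assay compound 2 gives 832 nM

Compound 2 holds the higher of the two numbers, so more of it is needed than of compound 1. Compound 3 `CCc1ccc(C(=O)NN(C(=O)C2CC=CCC2)C(C)(C)C)cc1` differs from compound 2 by cyclohex-3-en-1-yl in place of isopentyl on a carbonyl carbon. For the measured compounds named here, the only measured step that bears on this is a 170-fold higher number from compound 1 to compound 2 (2.23 log units; beyond the scatter), where a group with one six-membered ring on that carbonyl carbon was replaced by the isopentyl chain. A lower number is therefore expected for compound 3 because a 170-fold higher number from compound 1 to compound 2 (2.23 log units; beyond the scatter) ran the other way and the entering cyclohex-3-en-1-yl again brings one six-membered ring, giving an expected 14-fold lower number from compound 2 to compound 3 (1.14 log units; beyond the scatter). Compound 3 is estimated at 60 nM, within 12 nM to 300 nM.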

Compound 3, half-maximal effective concentration: 1000 nM
Compound 3: the middle estimate sits 17-fold (1.22 log units) below what was measured; measured number outside the range, above it.
By their numbers in this assay, from the lowest: compound 1; then compounds 2 and 3 (each within the scatter of the next).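

A six-membered ring on this carbonyl carbon is not enough by itself: cyclohex-3-en-1-yl in place of isopentyl gives a 1.2-fold higher number from compound 2 to compound 3 (0.08 log units; within the scatter), so the ring and the open chain cannot be told apart in this assay. Set against phenyl, the same ring gives a 200-fold higher number from compound 1 to compound 3 (2.31 log units; beyond the scatter), so among these three compounds only compound 1, with its phenyl, has a low number. Nothing measured here explains this difference. Still open, from the compounds shown here alone, is whether a fully saturated cyclohexyl or a pyridine ring at this place would stand with compound 1 or with compound 2 and compound 3.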